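Moving the sulfamoyl group on the benzylated core

The source may report more compounds than this note shows. Statements on the series, on what has been measured and on what is new or still open speak of the compounds shown alone.

Measured so far:
compound 1, `NS(=O)(=O)c1cccc(/N=C2\NC(=O)/C(=C3/C(=O)Nc4ccccc43)S2)c1` — > 200000 nM
compound 2, `NS(=O)(=O)c1ccc(/N=C2\NC(=O)/C(=C3/C(=O)N(Cc4ccccc4)c4ccccc43)S2)cc1` — > 200000 nM
compound 3, `NS(=O)(=O)c1ccc(/N=C2\NC(=O)/C(=C3/C(=O)Nc4ccccc43)S2)cc1` — > 200000 nM

In a functional assay on MCF7 cells (Homo sapiens) for antiproliferative activity, read by MTT assay (on this read-out lower numbers stand for stronger inhibition and higher numbers for weaker inhibition), compound 2 gives > 200000 nM, which is a limit of the assay and not a number. Compound 3 likewise gives only a limit, > 200000 nM. Compound 1 too gives only a limit, > 200000 nM. For the measured compounds named here, the one change that can be traced between measured compounds, a step that the two limits leave unreadable from compound 2 to compound 3, is hydrogen in place of benzyl on an amide-type nitrogen in a ring; its size cannot be read, because of the limit of > 200000 nM in this assay, at which 3 of the 3 values shown sit.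

Compound 4, `NS(=O)(=O)c1cccc(/N=C2\NC(=O)/C(=C3/C(=O)N(Cc4ccccc4)c4ccccc43)S2)c1`, is made from compound 2 by one rearrangement: 3-sulfamoylphenyl in place of 4-sulfamoylphenyl on a double-bonded nitrogen. The same exchange of 3-sulfamoylphenyl for 4-sulfamoylphenyl also separates compound 3 from compound 1, and both of those show only a limit, so the pair gives no readable size either. Going by the values given here, with no measured step bearing on this change, the expectation for a number no higher from compound 2 to compound 4 (the limit leaves the size open) is no step beyond the scatter, and compound 4 is expected to come out around 200000 nM, between 60000 nM and 200000 nM, most likely again as a limit.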

Compound 4, half-maximal inhibitory concentration: > 200000 nM
Compound 4 ended at the assay's limit (the forecaster's own chance of this, stated with the estimate: 85%); the middle value lies on the limit itself.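

Compound 4 adds no readable step from either compound 2 or compound 1, because these comparisons rest only on assay limits, not numbers: the limit of > 200000 nM in this assay, at which 4 of the 4 values shown sit.
The compounds shown leave open whether either the sulfamoyl exchange or the benzyl exchange changes antiproliferative activity at all.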